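Heteroaryl exchange on the chain carbon of compound 1

The source may report more compounds than this note shows. Statements on the series, on what has been measured and on what is new or still open speak of the compounds shown alone.

Compound 1 `Cc1nc(C)c(CN2CCN(c3cccc4[nH]c(-c5ccc(C(C)(C)C)cc5)nc34)CC2)o1` gives 31 nM in an assay on isolated protein for displacement of a labelled ligand from Gonadotropin-releasing hormone receptor (Homo sapiens); a higher number here means a weaker inhibitor, a lower number a stronger inhibitor; compound 2 `CCc1nc(C)c(CN2CCN(c3cccc4[nH]c(-c5ccc(C(C)(C)C)cc5)nc34)CC2)o1` gives 37 nM, and the step of a 1.2-fold higher number from compound 1 to compound 2 (0.08 log units; within the scatter) is within the scatter, so the two stand together. Compound 3 `Cc1n[nH]c(C)c1CN1CCN(c2cccc3[nH]c(-c4ccc(C(C)(C)C)cc4)nc23)CC1` differs from compound 1 by 3,5-dimethyl-1H-pyrazol-4-yl in place of 2,4-dimethyl-1,3-oxazol-5-yl on a saturated chain carbon bound to an amine nitrogen in a ring. Among the compounds with values here, the only measured step concerns a different change at a different place, so no measured step bears on this exchange, and neither size nor direction can be drawn from the data. The expected step is therefore a 1.3-fold higher number from compound 1 to compound 3 (0.11 log units; within the scatter), with no clear direction and a wide spread. Compound 3 is estimated at 40 nM in this assay, ranging from 12 nM to 130 nM.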

Compound 3, half-maximal inhibitory concentration: 68 nM
For compound 3 the middle estimate is 1.7-fold (0.23 log units) below the measured one; the range from low to high includes it.
By their numbers in this assay, from the lowest: compounds 1, 2 and 3 (each within the scatter of the next, the first and the last beyond it).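

Within the data shown here, exchanging 2,4-dimethyl-1,3-oxazol-5-yl for 3,5-dimethyl-1H-pyrazol-4-yl on the saturated chain carbon bound to an amine nitrogen in a ring gives a 2.2-fold higher number from compound 1 to compound 3 (0.34 log units; beyond the scatter) in this assay and is the first step beyond the scatter, though only a modest one. Measured against the 2-ethyl-4-methyl-1,3-oxazol-5-yl group, the pyrazolyl group gives a 1.8-fold higher number from compound 2 to compound 3 (0.26 log units; within the scatter) and so cannot be separated from that oxazolyl group. Nothing available explains the step from the oxazolyl to the pyrazolyl group.

On these data alone, whether a pyridyl ring or a 3,5-dimethyl-1,2-oxazol-4-yl group at this position would stay close to compound 1 remains open. Also open, as far as these compounds go, is whether the step follows the hydrogen-bond donor on the pyrazolyl group.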